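Swapping a pyridinylmethyl amine for a phenylpropyl amine

The source may hold more compounds than are shown below. What is called first, only, known or untested is meant among the compounds shown, and "the series" means these compounds.

The series shares one core, with an amine on the pyridine ring varied from compound to compound. Compound 1 `CSc1nc(-c2ccc(F)cc2)c(-c2ccnc(NCc3cccnc3)c2)[nH]1` carries a (pyridin-3-yl)methyl group on that nitrogen, and in a functional assay on blood (Homo sapiens) for inhibition (a higher number here means a weaker inhibitor, a lower number a stronger inhibitor), compound 1 reports "not determined" (no result reported), so no number places it on the scale. Compound 2 `CSc1nc(-c2cccc(C(F)(F)F)c2)c(-c2ccnc(NC(C)C(C)C)c2)[nH]1`, which bears a trifluoromethyl group on its phenyl ring and a branched alkyl amine, gives 1360 nM in this assay. Compound 3 `CSc1nc(-c2cccc(C(F)(F)F)c2)c(-c2ccnc(N[C@H](C)C3CCCCC3)c2)[nH]1`, with a cyclohexyl-bearing amine, reports "not determined" (no result reported) in this assay. Compound 4 `CCC(Nc1cc(-c2[nH]c(SC)nc2-c2ccc(F)cc2)ccn1)c1ccccc1` differs from compound 1 in one place: 1-phenylpropyl in place of (pyridin-3-yl)methyl on a nitrogen on an aromatic ring. Going by the values given here, with no measured step for this exchange and no number for compound 1, the size of the step cannot be read from the data; a branched amine in compound 2 at 1360 nM is the nearest point of reference. As far as these compounds go, compound 4 is therefore expected to fall near 800 nM in this assay, in a range from 150 nM to 4000 nM, with a direction relative to compound 1 that remains open.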

Compound 4, half-maximal inhibitory concentration: 7640 nM
Estimate against measurement, compound 4: 9.6-fold (0.98 log units) below, outside the stated range (above it).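

No step can be read between compound 1 and compound 4 in this assay, where compound 1 has no single number and compound 4 gives 7640 nM here. The compounds shown leave open what exchanging (pyridin-3-yl)methyl for 1-phenylpropyl does to inhibition, and no supporting finding bears on this result.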